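Ring-fused aminopyrimidine ureas: methoxy on the central ring

A few compounds are considered here, and "the series" means these few. Any claim that something is new, unique, unknown or untested is made for them only; others in the source may bear on it.

Measured in an assay on isolated protein for inhibition of proto-oncogene tyrosine-protein kinase receptor Ret variant V804L (Homo sapiens), read by 33P incorporation, with stated times of 15 min and 40 min; on this read-out higher numbers stand for weaker inhibition and lower numbers for stronger inhibition:
compound 1 `Cc1ccc(F)c(NC(=O)Nc2ccc(Nc3ncnc4c3OCCN4)cc2)c1`: 7000 nM
compound 2 `CC(C)(C)c1cc(NC(=O)Nc2ccc(Nc3ncnc4c3OCCN4)cc2)no1`: 58 nM
compound 3 `CC(C)(C)c1cc(NC(=O)Nc2ccc(Nc3ncnc4c3OCCN4)cc2F)no1`: 95 nM

Within the data shown here, compound 2 gives the lowest number of the three in this assay, though the step of a 1.6-fold higher number from compound 2 to compound 3 (0.21 log units; within the scatter) stays within the scatter, so it cannot be ranked against compound 3; only the step of a 120-fold lower number from compound 1 to compound 2 (2.08 log units; beyond the scatter) sets it clearly apart.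

Compound 4 `COc1cc(NC(=O)Nc2cc(C(C)(C)C)on2)ccc1Nc1ncnc2c1OCCN2` differs from compound 2 by methoxy in place of hydrogen on an aromatic carbon. Among the measured compounds shown here, the nearest precedent is the substitution on the same central ring, a 1.6-fold higher number from compound 2 to compound 3 (0.21 log units; within the scatter), which stayed within the scatter; the large step of a 120-fold lower number from compound 1 to compound 2 (2.08 log units; beyond the scatter) concerns a different part of the molecule and does not bear on this change. A step of no more than the scatter is therefore expected in this assay, with a slight lean toward a higher number, estimated as a 1.3-fold higher number from compound 2 to compound 4 (0.11 log units; within the scatter).

Compound 4 is expected to give 75 nM in this assay, in the range 30 nM to 180 nM.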

Compound 4, half-maximal inhibitory concentration: 29 nM
Compound 4: middle estimate off by 2.6-fold (0.41 log units), on the high side; the whole stated range lies above it.
By their numbers in this assay, from the lowest: compounds 4, 2 and 3 (each within the scatter of the next, the first and the last beyond it); then compound 1.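

In this assay, methoxy on an aromatic carbon of the central ring, ortho to a large group and meta to a large group, is tolerated: a 2.0-fold lower number from compound 2 to compound 4 (0.30 log units; within the scatter). This position therefore takes a group of 2 heavy atoms, including 1 hydrogen-bond acceptor, with no step beyond the scatter, which the fluoro of compound 3 could not show. No measurement at hand accounts for this step.

From the compounds shown here alone, whether ethoxy or a dimethylamino group at this position would also stay within the scatter remains open. Also open, going by these compounds, is whether methoxy would behave the same alongside the 2-fluoro-5-methylphenyl of compound 1.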